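Methyl for Fluoro on the Pendant Phenyl Ring

The source may hold more compounds than are shown below. What is called first, only, known or untested is meant among the compounds shown, and "the series" means these compounds.

Compound 1 `Cc1cnc(Nc2ccc(C(=O)Nc3c(C)cccc3C)cc2)nc1-c1cccc(OC(F)(F)F)c1` gives 1.2 nM in an assay on NIH3T3 cells for inhibition of Sonic hedgehog protein (Mus musculus), read by a luciferase reporter, with a stated time of 48 h; on this read-out lower numbers stand for stronger inhibition and higher numbers for weaker inhibition.
Compound 2 `Cc1cnc(Nc2ccc(C(=O)Nc3c(C)cccc3C)cc2)nc1-c1ccccc1OC(F)(F)F` gives > 500 nM, which is a limit of this assay, not a number.
Compound 3 `Cc1cnc(Nc2ccc(C(=O)Nc3c(C)cccc3C)cc2)nc1-c1ccc(F)cc1` gives 2.2 nM.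

Of the two numbers measured, compound 3 has the higher one, yet its nearest neighbour, compound 1, lies within the scatter of it: a 1.8-fold higher number from compound 1 to compound 3 (0.26 log units; within the scatter). Compound 2 stands only at a limit (the limit of > 500 nM in this assay, at which 1 of the 3 values shown sits).

Compound 4 `Cc1ccc(-c2nc(Nc3ccc(C(=O)Nc4c(C)cccc4C)cc3)ncc2C)cc1` has not been measured. It differs from compound 3 by a single change: methyl in place of fluoro on an aromatic carbon, on an aromatic carbon of a six-membered aromatic ring of carbon only, para to a large group.

Among the compounds with values here, no measured step makes exactly this exchange. Within the data shown here, two steps touch the same ring. The move a 1.8-fold higher number from compound 1 to compound 3 (0.26 log units; within the scatter) swapped a 3-(trifluoromethoxy)phenyl for a 4-fluorophenyl without leaving the scatter. The move an at least 410-fold higher number from compound 1 to compound 2 (2.61 log units; beyond the scatter) and the move an at least 220-fold lower number from compound 2 to compound 3 (2.35 log units; beyond the scatter) show that a 2-(trifluoromethoxy)phenyl on this ring pushes the value to a limit. Since compound 4 keeps a small group at the same place as the fluoro of compound 3, the expected step of a 1.1-fold higher number from compound 3 to compound 4 (0.06 log units; within the scatter) is no larger than the scatter.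

Compound 4 is therefore estimated at 2.5 nM, expected to fall between 0.8 nM and 8 nM.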

Compound 4, half-maximal inhibitory concentration: > 500 nM
Compound 4: only a limit was reported (the forecaster's own chance of this, stated with the estimate: 5%); middle value at least 200-fold (2.30 log units) away from the limit.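

The place para to a large group turns out to be far less forgiving than compounds 1 and 3 suggested: in this assay, methyl in place of fluoro, with the same count of heavy atoms and no added hydrogen-bond donors or acceptors, gives an at least 220-fold higher number from compound 3 to compound 4 (2.35 log units; beyond the scatter). Until now, only the 2-(trifluoromethoxy)phenyl had pushed the value to the limit, whereas the 3-(trifluoromethoxy)phenyl and 4-fluorophenyl stayed within the scatter of each other; the 4-methylphenyl now joins the 2-(trifluoromethoxy)phenyl, with an at least 410-fold higher number from compound 1 to compound 4 (2.61 log units; beyond the scatter). Compound 4 gives > 500 nM, which is a limit and not a number, and compound 2 sits at the same limit, so the step between these two cannot be read: the limit of > 500 nM in this assay, at which 2 of the 4 values shown sit.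

As far as these compounds go, how much weaker compound 4 really is stays unknown, since both large steps are only minimum sizes. Also open, from the compounds shown here alone, is whether this place tolerates little beyond fluoro, or whether chloro, a hydroxyl, a methoxy or an amine there would keep a value close to that of compound 3, which gives 2.2 nM.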